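The source may hold more compounds than are shown below. What is called first, only, known or untested is meant among the compounds shown, and "the series" means these compounds.

Measured in an ADME assay on HFF cells (Homo sapiens) for cytotoxicity, read by MTT assay, with a stated time of 72 h; a lower number here means a stronger inhibitor, a higher number a weaker inhibitor:
compound 1 `O=C1O[C@H]([C@@H](O)Cn2cc(-c3ccc(Br)cc3)nn2)C(OCc2ccccc2)=C1OCc1ccccc1`: 5100 nM
compound 2 `O=C1O[C@H]([C@@H](O)Cn2cc(C3CC3)nn2)C(OCc2ccccc2)=C1OCc1ccccc1`: 24300 nM
compound 3 `O=C1O[C@H]([C@@H](O)Cn2cc(CCCCl)nn2)C(OCc2ccccc2)=C1OCc1ccccc1`: 27100 nM

Compound 3 stands at the high end of these three numbers. It is level within the scatter with its nearest neighbour: a 1.1-fold higher number from compound 2 to compound 3 (0.05 log units; within the scatter). The gap to the bromophenyl compound is clear: a 5.3-fold higher number from compound 1 to compound 3 (0.73 log units; beyond the scatter).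

Compound 4 `O=C1O[C@H]([C@@H](O)Cn2ccnn2)C(OCc2ccccc2)=C1OCc1ccccc1` is the open structure. The change is hydrogen in place of 3-chloropropyl on an aromatic carbon, in words hydrogen in place of 3-chloropropyl on an aromatic carbon of a five-membered aromatic ring with 3 nitrogen.

Among the compounds with values here, no measured step puts hydrogen at this place, so the evidence is indirect. Replacing 4-bromophenyl gave modest steps: a 4.8-fold higher number from compound 1 to compound 2 (0.68 log units; beyond the scatter) and a 5.3-fold higher number from compound 1 to compound 3 (0.73 log units; beyond the scatter). Exchanging cyclopropyl for 3-chloropropyl gave nothing beyond the scatter: a 1.1-fold higher number from compound 2 to compound 3 (0.05 log units; within the scatter). Within the data shown here, with only three compounds, this is a weak guide. In this assay, a small rise in the number is expected, probably not beyond the scatter and unlikely to exceed the modest steps seen so far.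

The estimated step is a 1.4-fold higher number from compound 3 to compound 4 (0.15 log units; within the scatter). For compound 4 the expected value is 38000 nM, with an estimated range of 17000 nM to 85000 nM.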

Compound 4, half-maximal inhibitory concentration: 610 nM
Compound 4: the middle estimate sits 62-fold (1.79 log units) above what was measured, and the stated range ends above it.
By their numbers in this assay, from the lowest: compound 4; then compound 1; then compounds 2 and 3 (each within the scatter of the next).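

In this assay, within the data shown here, the earlier compounds only set groups against each other; taking the group away altogether gives a 44-fold lower number from compound 3 to compound 4 (1.65 log units; beyond the scatter) and a 40-fold lower number from compound 2 to compound 4 (1.60 log units; beyond the scatter) as large steps, so this place on an aromatic carbon of the five-membered aromatic ring with 3 nitrogen is far from neutral for the number. Even the 4-bromophenyl compound, the low end until now, lies clearly higher, with an 8.4-fold lower number from compound 1 to compound 4 (0.92 log units; beyond the scatter) as a modest step, so among these four compounds each of the three groups goes with a higher number than hydrogen, and no compound goes against that. Nothing measured here explains why hydrogen stands apart from all three groups.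

Three groups cannot say whether the number climbs gradually from hydrogen or jumps with any group at all; a methyl, a hydroxymethyl or a short amine chain at this place would separate those two readings. Also open, as far as these compounds go, is whether the gap between 4-bromophenyl and the cyclopropyl and 3-chloropropyl groups holds for other aromatic groups such as plain phenyl, or for a chain ending in a carboxylic acid.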